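Chain chloro to acetoxy: expected cytotoxicity of compound 3

This account rests on a few compounds, and the source may have more. Where it says the series, first, only, none or still open, it means among the compounds named here.

Compound 1, `ClCCc1c(Cl)nc2ccc(Cl)cc2c1-c1ccccc1Cl`, in an ADME assay on HepG2 2.2.15 cells (Homo sapiens) for cytotoxicity (a higher number here means that more compound is tolerated, a lower number that less compound is tolerated), gives > 1400000 nM.
Compound 2, `CS(=O)(=O)OCCc1c(OS(C)(=O)=O)nc2ccc(Cl)cc2c1-c1ccccc1Cl`, in this assay gives 804000 nM.

The value of compound 1 is only a limit of the assay, and it stands at the limit of > 1400000 nM in this assay, at which 1 of the 2 values shown sits. Compound 3, `CC(=O)OCCc1c(Cl)nc2ccc(Cl)cc2c1-c1ccccc1Cl`, differs from compound 1 by acetoxy in place of chloro on a saturated chain carbon, two bonds along the chain from an aromatic carbon. Within the data shown here, no measured pair covers this change, so the step is expected to stay within the scatter, as an at least 1.1-fold lower number from compound 1 to compound 3 (0.06 log units; that floor lies within the scatter). Compound 3 is therefore estimated at 1200000 nM, with a range from 500000 nM to 2500000 nM.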

Compound 3, half-maximal cytotoxic concentration: 116000 nM
The estimate for compound 3 lay 10-fold (1.01 log units) above the measured number, and the stated range ends above it.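

In this assay, the chain carbon two bonds from an aromatic carbon proves sensitive to what it carries: acetoxy in place of chloro gives an at least 12-fold lower number from compound 1 to compound 3 (1.08 log units; beyond the scatter). This step is a floor, not a measured size, since the value of compound 1 is only a limit of the assay: the limit of > 1400000 nM in this assay, at which 1 of the 3 values shown sits.

The compounds shown leave open whether the shift is specific to acetoxy or would also appear with a hydroxy group, an amine or a longer chain at this place. They also leave open how far the step extends beyond that floor.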